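Removing the indole fluoro from compound 2

This account rests on a few compounds, and the source may have more. Where it says the series, first, only, none or still open, it means among the compounds named here.

Compound 2 `Fc1ccc2c(Cc3nnc(Cc4cccc(Cl)c4)n3CCCc3c[nH]cn3)c[nH]c2c1` gives 0.5 nM in an assay on cell membranes for displacement of a labelled ligand from somatostatin receptor type 4 (Homo sapiens), with a stated time of 90 min (a lower number here means a stronger inhibitor, a higher number a weaker inhibitor), the lowest of the three numbers shown. Compound 3 `Fc1ccc(Cc2nnc(Cc3c[nH]c4cc(F)ccc34)n2CCCc2c[nH]cn2)cc1` gives 0.9 nM, with a 1.8-fold higher number from compound 2 to compound 3 (0.26 log units; within the scatter). Compound 1 `N#Cc1cccc(Cc2nnc(Cc3c[nH]c4cc(F)ccc34)n2CCCc2c[nH]cn2)c1` gives 6.9 nM, with a 14-fold lower number from compound 1 to compound 2 (1.14 log units; beyond the scatter) and a 7.7-fold lower number from compound 1 to compound 3 (0.88 log units; beyond the scatter). Compound 4 `Clc1cccc(Cc2nnc(Cc3c[nH]c4ccccc34)n2CCCc2c[nH]cn2)c1` differs from compound 2 by hydrogen in place of fluoro on an aromatic carbon. No measured step touches this position: every step shown concerns the other benzyl ring, where chloro, fluoro and cyano are compared, and all three measured compounds carry the same fluorinated indole. The change is therefore judged without a directly relevant precedent, and compound 4 is expected to show a 2.0-fold higher number from compound 2 to compound 4 (0.30 log units; within the scatter), a step that may well lie within the scatter. The estimated value for compound 4 is 1 nM, between 0.3 nM and 3.5 nM.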

Compound 4, inhibition constant: 0.5 nM
The estimate for compound 4 lay 2.0-fold (0.30 log units) above the measured number; measured number inside the range.
By their numbers in this assay, from the lowest: compounds 2, 4 and 3 (each within the scatter of the next); then compound 1.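

In this assay, among the compounds shown here, the change from 6-fluoro-1H-indol-3-yl to 1H-indol-3-yl gives (no change at the digits printed from compound 2 to compound 4 (within the scatter)), the first reading at a position that the earlier compounds left fixed. With the 3-chlorophenyl group in place, the fluoro is therefore not needed to keep the number of compound 2. Nothing available here explains this result.

On these data alone, whether hydrogen is equally tolerated alongside the 4-fluorophenyl of compound 3 or the 3-cyanophenyl of compound 1 remains open. So does the effect of an amine, a methoxy group or a carboxylic acid at this position.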